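The compounds below may be only part of what the source reports. "The series", "measured", "known", "first", "only" and "open" are said of these compounds alone.

In an assay on isolated protein (Oryctolagus cuniculus) with Thromboxane-A synthase (Homo sapiens) as the target, tested at 1 uM (a higher number here means more inhibition at the concentration tested (going by the name of the read-out), a lower number less inhibition), compound 2 `CCOC(=O)Cn1nc(-c2cccnc2)c2ccccc2c1=O` gives 28%, the lowest of the two numbers seen, while compound 1 `O=c1c2ccccc2c(-c2cccnc2)nn1CC1CCCCC1` gives 98%. Going by the values given here, the one measured step, a number 70 percentage points lower from compound 1 to compound 2 (beyond the scatter), shows how much the ethoxycarbonyl on a saturated chain carbon bound to an aromatic nitrogen costs against cyclohexyl in that place. Compound 3 `O=c1c2ccccc2c(-c2cccnc2)nn1CCSc1nccs1` differs from compound 2 in ((1,3-thiazol-2-yl)sulfanyl)methyl in place of ethoxycarbonyl on a saturated chain carbon bound to an aromatic nitrogen. That step bears on the new change only in that the ethoxycarbonyl leaves again, so a large rise is expected. Compound 3 is estimated at 72%, between 40% and 95%, an expected step of a number 44 percentage points higher from compound 2 to compound 3 (beyond the scatter).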

Compound 3, a percentage reported as inhibition, at one concentration (the size of the read-out at that concentration, not a potency): 97%
Estimate against measurement, compound 3: 25 percentage points below; the whole stated range lies below it.
By their numbers in this assay, from the lowest: compound 2; then compounds 3 and 1 (each within the scatter of the next).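

In this assay the place on a saturated chain carbon bound to an aromatic nitrogen shows a number 69 percentage points higher from compound 2 to compound 3 (beyond the scatter) and also a number 1 percentage points lower from compound 1 to compound 3 (within the scatter), so the high reading is not tied to cyclohexyl. Among these three compounds, only the one with ethoxycarbonyl stands low, although ((1,3-thiazol-2-yl)sulfanyl)methyl and cyclohexyl are very different groups. No evidence at hand explains this result.

Going by these compounds, it remains open whether the thiazole ring or the sulfur carries the reading, which a plain phenyl or an ethylsulfanyl group in its place would separate. A carboxylic acid or an amine at this place also remains untested among the compounds shown.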